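Methyl in Place of Chloro: an Expected Lipase Value

A few compounds are considered here, and "the series" means these few. Any claim that something is new, unique, unknown or untested is made for them only; others in the source may bear on it.

Compound 1 `Cc1c(C(C)C)c(=O)on1C(=O)Nc1ccccc1` gives in an assay (strain Wistar) for inhibition of Hormone-sensitive lipase (Rattus norvegicus), read by spectrophotometry (a higher number here means a weaker inhibitor, a lower number a stronger inhibitor), a value of > 1000 nM, which is a limit of the assay.
Compound 2 `CSc1nc(-c2ccc(Cl)cc2)nn1C(=O)N(C)c1ccccc1` gives in this assay 2.82 nM.
Compound 3 `CCCCCCSc1nc(-c2ccc(Cl)cc2)nn1C(=O)N(C)c1ccccc1` gives in this assay 7.06 nM.

For the measured compounds named here, compound 3 thus holds the higher of the two numbers in this assay, the only measured step being a 2.5-fold higher number from compound 2 to compound 3 (0.40 log units; beyond the scatter), a change on the sulfur chain. Compound 1 sits at the limit of > 1000 nM in this assay, at which 1 of the 3 values shown sits.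

Compound 4 `CCCCCCSc1nc(-c2ccc(C)cc2)nn1C(=O)N(C)c1ccccc1` differs from compound 3 by methyl in place of chloro on an aromatic carbon. No measured step touches the six-membered carbon ring, so nothing among the shown values bears directly on this change. Compound 4 is therefore expected to stay close to compound 3, with the step of a 1.4-fold higher number from compound 3 to compound 4 (0.15 log units; within the scatter) judged to lie within or near the scatter. The estimate for compound 4 in this assay is 10 nM, with a range from 3 nM to 40 nM.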

Compound 4, half-maximal inhibitory concentration: 12.4 nM
The estimate for compound 4 lay 1.2-fold (0.09 log units) below the measured number, within the range that was stated.
By their numbers in this assay, from the lowest: compound 2; then compounds 3 and 4 (each within the scatter of the next). At a limit, above all of these: compound 1.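

In this assay, for the compounds shown here, the change from 4-chlorophenyl to 4-methylphenyl gives a 1.8-fold higher number from compound 3 to compound 4 (0.24 log units; within the scatter) and is the first measured step at this place on the six-membered aromatic ring. Chloro and methyl are therefore not told apart here in this assay. Nothing shown explains this result.

The compounds shown leave open whether an amine, a carboxylic acid or a methoxy group at this place would keep the number in the same range. They also leave open whether the same change would read alike on compound 2.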